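The source may hold more compounds than are shown below. What is called first, only, known or untested is meant among the compounds shown, and "the series" means these compounds.

Measured so far in a functional assay on HepG2 cells (Homo sapiens) for antiproliferative activity, read by MTT assay, with a stated time of 24 h; a higher number here means a weaker inhibitor, a lower number a stronger inhibitor

Compound 1 `C=CCOc1ccc2c(=O)c(-c3cc(OC)c(OC)cc3OC)coc2c1` gives 3450 nM
Compound 2 `COc1cc(OC)c(-c2coc3cc(OCc4ccccc4)ccc3c2=O)cc1OC` gives 1320 nM
Compound 3 `COc1cc(OC)c(-c2coc3cc(OCC(=O)c4cccc(C(F)(F)F)c4)ccc3c2=O)cc1OC` gives > 10000 nM as a limit

Compound 3 has no number of its own and is known only through the limit of > 10000 nM in this assay, at which 1 of the 3 values shown sits, in this small set. Compound 4 `COc1cc(OC)c(-c2coc3cc(OCc4ccc(F)cc4)ccc3c2=O)cc1OC` carries 4-fluorophenyl in place of (3-(trifluoromethyl)phenyl)carbonyl on a saturated chain carbon bound to an oxygen on an aromatic ring.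

Among the measured compounds shown here, three measured steps bear on this change. The closest is the one in which (3-(trifluoromethyl)phenyl)carbonyl replaced phenyl (an at least 7.5-fold higher number from compound 2 to compound 3 (0.87 log units; beyond the scatter)). The same group in place of vinyl moved the number the same way (an at least 2.8-fold higher number from compound 1 to compound 3 (0.46 log units; beyond the scatter)), while phenyl in place of vinyl lowered it (a 2.6-fold lower number from compound 1 to compound 2 (0.42 log units; beyond the scatter)). Compound 4 keeps an aromatic ring on that chain carbon without the carbonyl, so it is expected to read like compound 2 at 1320 nM and not like compound 3. For the measured compounds named here, no measured step isolates the fluorine of the 4-fluorophenyl, so the expectation is simply the closest step run in reverse, of similar size and beyond the scatter, toward a lower number.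

The step expected is (an at least 6.6-fold lower number from compound 3 to compound 4 (0.82 log units; beyond the scatter)).

In this assay the estimate for compound 4 is 1500 nM (expected range 500 nM to 5000 nM).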

Compound 4, half-maximal inhibitory concentration: 1000 nM
For compound 4 the middle estimate is 1.5-fold (0.18 log units) above the measured one; measured number inside the range.
By their numbers in this assay, from the lowest: compounds 4 and 2 (each within the scatter of the next); then compound 1. At a limit, above all of these: compound 3.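

In this assay, fluoro in place of hydrogen on an aromatic carbon gives a 1.3-fold lower number from compound 2 to compound 4 (0.12 log units; within the scatter), so the fluorine makes no difference that can be told here. Taking vinyl as the reference, 4-fluorophenyl in its place gives a 3.5-fold lower number from compound 1 to compound 4 (0.54 log units; beyond the scatter), in the same direction as the plain phenyl change, a 2.6-fold lower number from compound 1 to compound 2 (0.42 log units; beyond the scatter), and a second ring-bearing compound now reads lower than the vinyl one. Going from (3-(trifluoromethyl)phenyl)carbonyl to 4-fluorophenyl on the saturated chain carbon bound to an oxygen on an aromatic ring gives an at least 10-fold lower number from compound 3 to compound 4 (1.00 log units; beyond the scatter), a step read against a limit and not against a number: the limit of > 10000 nM in this assay, at which 1 of the 4 values shown sits.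

The carbonyl and the trifluoromethyl change together in the compounds shown, so which of the two goes with the weak reading remains open, and a plain phenylcarbonyl group would be needed to separate them. Also open, from the compounds shown here alone, is how an amine, a carboxylic acid or a longer chain would read on that same saturated chain carbon in this assay.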